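The source may hold more compounds than are shown below. What is called first, only, known or untested is meant among the compounds shown, and "the series" means these compounds.

Compound 1 `Nc1ccc(C#Cc2c(F)cccc2F)cc1` is the starting point of this set. In a functional assay on LS174T cells (Homo sapiens) for antiproliferative activity, with a stated time of 4 days (a lower number here means a stronger inhibitor, a higher number a weaker inhibitor), compound 1 gives 55 nM. Compound 2 `CNc1ccc(C#Cc2c(F)cccc2F)cc1` keeps the same core and differs only at the nitrogen: a 2.4-fold lower number from compound 1 to compound 2 (0.38 log units; beyond the scatter), and in this assay compound 2 gives 23 nM. Compound 3 `CN(C)c1ccc(C#Cc2ccccc2)cc1` carries a dimethylated nitrogen and no fluorine. For compound 3, this assay reports only a limit, > 3000 nM, so its place among the numbers is not known beyond that; this is the limit of > 3000 nM in this assay, at which 1 of the 3 values shown sits. Compound 3 therefore stands apart from compound 1 and compound 2, both of which give measured values well inside the range of this assay.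

Compound 4 `CN(C)c1ccc(C#Cc2ccccc2F)cc1` differs from compound 3 in one place: fluoro in place of hydrogen on an aromatic carbon. Going by the values given here, no measured step covers this change, since the single measured step, a 2.4-fold lower number from compound 1 to compound 2 (0.38 log units; beyond the scatter), concerns the nitrogen and not the aromatic ring. What can be said is that compound 2, which carries fluorine on that ring, gives 23 nM. Compound 3, without fluorine, has only a limit in this assay. On that basis compound 4 is expected to show a step of an at least 2.0-fold lower number from compound 3 to compound 4 (0.30 log units; that floor lies within the scatter) in this assay, though with wide uncertainty. The estimate for compound 4 in this assay is 1500 nM, with a range from 200 nM to 6000 nM.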

Compound 4, half-maximal inhibitory concentration: 39 nM
Compound 4: middle estimate off by 38-fold (1.59 log units), on the high side, outside the stated range (below it).
By their numbers in this assay, from the lowest: compounds 2, 4 and 1 (each within the scatter of the next, the first and the last beyond it). At a limit, above all of these: compound 3.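

Fluoro in place of hydrogen on an aromatic carbon, ortho to a large group, is the first change here that takes a compound from a limit to a measured value in this assay, and it gives an at least 76-fold lower number from compound 3 to compound 4 (1.88 log units; beyond the scatter). Going by these compounds alone, until now the only measured step lay at the nitrogen, a 2.4-fold lower number from compound 1 to compound 2 (0.38 log units; beyond the scatter), so this result is the first direct reading of a change on the aromatic ring, and it shows that a single fluoro at this position is enough for a large step. As far as these compounds go, the true size of that step stays open, with only a floor to be read, because compound 3 is held at a limit: the limit of > 3000 nM in this assay, at which 1 of the 4 values shown sits.

The compounds shown leave open whether this step belongs to fluoro as such, or whether chloro, methyl or methoxy on the same aromatic carbon would give a comparable reading. They also leave open how a second fluoro on that ring, or a hydroxyl or a carboxylic acid in that place, would read with the dimethylated nitrogen kept.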